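The source may report more compounds than this note shows. Statements on the series, on what has been measured and on what is new or still open speak of the compounds shown alone.

Measured so far:
- compound 1 `O=C(/C=C/c1ccco1)c1ccc(NC(=O)c2ccccc2)cc1`: 76000 nM
- compound 2 `O=C(/C=C/c1cccc([N+](=O)[O-])c1)c1ccc(NC(=O)c2ccco2)cc1`: 3500 nM
- compound 3 `O=C(/C=C/c1cccc([N+](=O)[O-])c1)c1ccc(NC(=O)c2cccs2)cc1`: 2500 nM

In a functional assay on HT-29 cells (Homo sapiens) for cytotoxicity, read by resazurin assay, with a stated time of 48 h (a lower number here means that less compound is needed, a higher number that more compound is needed for the effect), compound 3 holds the lowest of the three numbers, but its nearest neighbour, compound 2, sits within the scatter of it, so the two cannot be ranked. Compound 1 lies far above both, beyond the scatter, and it differs from compound 3 in more than one place, so its value says nothing clean about any single change.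

The next compound, compound 4 `O=C(/C=C/c1cccc([N+](=O)[O-])c1)c1ccc(NC(=O)c2ccccc2)cc1`, differs from compound 3 by one change: phenyl in place of thiophen-2-yl on a carbonyl carbon. Among the measured compounds shown here, the only measured step that touches this position is a 1.4-fold lower number from compound 2 to compound 3 (0.15 log units; within the scatter), an exchange of one five-membered heteroaryl for another on the same carbonyl carbon, which stayed within the scatter. For the measured compounds named here, compound 1 carries the benzamido group that enters here, but it also differs in the nitro group and the furan-2-yl on the enone side, so no step to it can be drawn. On this basis compound 4 is expected to show no change beyond the scatter in this assay, the estimated step being a 1.2-fold higher number from compound 3 to compound 4 (0.08 log units; within the scatter). Compound 4 is therefore estimated at 3000 nM, with a range from 1200 nM to 8000 nM.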

Compound 4, half-maximal effective concentration: 3900 nM
Estimate against measurement, compound 4: 1.3-fold (0.11 log units) below, within the range that was stated.
By their numbers in this assay, from the lowest: compounds 3, 2 and 4 (each within the scatter of the next); then compound 1.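

In this assay, the carbonyl carbon bound to the amide-type nitrogen now carries a six-membered aromatic ring of carbon only as well as the two five-membered heteroaryl groups, and the size of the ring makes no readable difference: a 1.6-fold higher number from compound 3 to compound 4 (0.19 log units; within the scatter) and a 1.1-fold higher number from compound 2 to compound 4 (0.05 log units; within the scatter) both stay within the scatter, so phenyl, thiophen-2-yl and furan-2-yl cannot be ranked at this position. Compound 4 also gives the first single-place link to compound 1, and a 19-fold lower number from compound 1 to compound 4 (1.29 log units; beyond the scatter), beyond the scatter, places the large gap in the exchange of furan-2-yl for 3-nitrophenyl on the double-bonded chain carbon, with the benzamido group held constant. Nothing available here explains either result.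

On these data alone, whether this position tolerates any group in this assay remains open, since an amine or a carboxylic acid on the benzoyl ring, or a longer chain on that carbonyl carbon, could still produce a step beyond the scatter. As far as these compounds go, it is also open how much of the large step belongs to the nitro group itself, which a plain phenyl or an amine-bearing phenyl on the chain carbon would separate from the ring exchange.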